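A few compounds are considered here, and "the series" means these few. Any claim that something is new, unique, unknown or untested is made for them only; others in the source may bear on it.

Working notes on the series. Among the measured compounds shown here, in a functional assay on HL-60 cells (Homo sapiens) for cytotoxicity, read by luminescence and CellTiter-Glo, with a stated time of 3 days (a lower number here means a stronger inhibitor, a higher number a weaker inhibitor), compound 2 (`N#Cc1ccc(NC(=O)c2ccccc2O)cc1`) gives 4620 nM, the only true number so far. Compound 1 (`COc1cccc(C(=O)Nc2ccc(C#N)cc2)c1O`) reads > 10000 nM, which is a limit of the assay and not a number.

The next structure is compound 3 (`N#Cc1ccc(NC(=O)c2cccc(F)c2O)cc1`), which differs from compound 2 as follows: fluoro in place of hydrogen on an aromatic carbon. Fluoro replaces hydrogen on an aromatic carbon, ortho to a hydroxy group and meta to a large group.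

For the measured compounds named here, only one measured step bears on this change. It touches the same aromatic carbon: an at least 2.1-fold lower number from compound 1 to compound 2 (0.33 log units; beyond the scatter), with hydrogen in place of methoxy. That step is a bound rather than a full size, as it rests on (the limit of > 10000 nM in this assay, at which 1 of the 2 values shown sits). Going by the values given here, it shows that a substituent at this carbon can matter in this assay, but it concerns methoxy and not fluoro, and no measured compound carries fluoro. The step from compound 1 to compound 2 therefore gives no firm direction here, and a small change is expected, probably within the scatter.

The expected step is a 1.2-fold lower number from compound 2 to compound 3 (0.06 log units; within the scatter). Compound 3 is estimated at 4000 nM, with an expected range from 1500 nM to 10000 nM.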

Compound 3, half-maximal inhibitory concentration: 5390 nM
For compound 3 the middle estimate is 1.3-fold (0.13 log units) below the measured one, and the stated range covers the measured number.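

In this assay, the change to fluoro on this aromatic carbon, ortho to a hydroxy group, gives a 1.2-fold higher number from compound 2 to compound 3 (0.07 log units; within the scatter), so compound 3 cannot be told apart from compound 2. Among the compounds shown here, this is the first full-sized step at this position, and it shows that here fluoro can stand in place of hydrogen with no change beyond the scatter, which the earlier methoxy step could not show. Fluoro in place of methoxy gives an at least 1.8-fold lower number from compound 1 to compound 3 (0.26 log units; that floor lies within the scatter), so unlike the floor of the step from methoxy to hydrogen, this floor does not clear the scatter, and the step is a bound and not a full size, as it rests on a limit of the assay: the limit of > 10000 nM in this assay, at which 1 of the 3 values shown sits.

On these data alone, only hydrogen, fluoro and methoxy appear at this carbon, so the effect of chloro, an amine or a longer alkoxy chain there remains open. Also open, as far as these compounds go, is what happens when the hydroxy group gives way to an amine, or the nitrile to a carboxylic acid, since both groups stay fixed across compound 1, compound 2 and compound 3.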